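The source may report more compounds than this note shows. Statements on the series, on what has been measured and on what is new or still open speak of the compounds shown alone.

Measured compounds in an ADME assay on NIH3T3 cells (Mus musculus) for cytotoxicity, read by MTT assay, with a stated time of 24 h; a lower number here means a stronger inhibitor, a higher number a weaker inhibitor:
compound 1 `O=C(CSc1nnc(-c2ccncc2)o1)N/N=C/c1ccccc1` gives 167000 nM
compound 2 `O=C(CSc1nnc(-c2ccncc2)o1)N/N=C/c1ccc([N+](=O)[O-])cc1` gives 195000 nM
compound 3 `O=C(CSc1nnc(-c2ccncc2)o1)N/N=C/c1cc(Cl)cc(Cl)c1O` gives 171000 nM

On the numbers shown, compound 3 cannot be set apart from the other two: the steps of a 1.0-fold higher number from compound 1 to compound 3 (0.01 log units; within the scatter) and a 1.1-fold lower number from compound 2 to compound 3 (0.06 log units; within the scatter) are both within the scatter, as is a 1.2-fold higher number from compound 1 to compound 2 (0.07 log units; within the scatter). All three compounds share one core and differ only in the aryl group on the carbon with a double bond to nitrogen, and none of these exchanges has moved this assay beyond the scatter.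

Compound 4 `O=C(CSc1nnc(-c2ccncc2)o1)N/N=C/c1ccc(O)c(O)c1` continues this pattern of exchange: 3,4-dihydroxyphenyl in place of 3,5-dichloro-2-hydroxyphenyl on a carbon with a double bond to nitrogen. Among the measured compounds shown here, the steps that bear on it are a 1.0-fold higher number from compound 1 to compound 3 (0.01 log units; within the scatter) and a 1.1-fold lower number from compound 2 to compound 3 (0.06 log units; within the scatter), each an exchange of the same aryl group at the same place, and each within the scatter. No shown step gives grounds to expect a move in either direction in this assay from compound 3 to compound 4 beyond the scatter.

Compound 4 is therefore estimated at 175000 nM, with a range from 90000 nM to 350000 nM. This estimate means an expected step of a 1.0-fold higher number from compound 3 to compound 4 (0.01 log units; within the scatter), within the scatter.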

Compound 4, half-maximal inhibitory concentration: 154000 nM
Beside the measured number, compound 4's estimate is 1.1-fold (0.06 log units) above it; the range from low to high includes it.
By their numbers in this assay, from the lowest: compounds 4, 1, 3 and 2 (each within the scatter of the next).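

At the carbon with a double bond to nitrogen, 3,4-dihydroxyphenyl joins phenyl, 4-nitrophenyl and 3,5-dichloro-2-hydroxyphenyl in this assay, and it stays within the scatter of all three (a 1.1-fold lower number from compound 1 to compound 4 (0.04 log units; within the scatter) and a 1.3-fold lower number from compound 2 to compound 4 (0.10 log units; within the scatter) and a 1.1-fold lower number from compound 3 to compound 4 (0.05 log units; within the scatter)). An aryl group without chlorine and with 2 hydrogen-bond donors therefore cannot be told apart from one with chlorine and 1 hydrogen-bond donor, so the range of aryl groups at this place is wider than before, with still no step beyond the scatter. No measured evidence is available to explain this result.

Still open, going by these compounds, is whether an aryl group carrying an amine or a carboxylic acid, or a longer alkyl chain in place of the aryl group, would move this assay beyond the scatter. Also open, on these data alone, is whether an exchange elsewhere in the shared core would do so.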